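The compounds below may be only part of what the source reports. "The series", "measured", "known", "first", "only" and "open" are said of these compounds alone.

Measured in a functional assay on HepG2 cells (Homo sapiens) for inhibition, read by MTT assay, with a stated time of 48 h; on this read-out lower numbers stand for stronger inhibition and higher numbers for weaker inhibition:
Compound 1 `CCc1ccc(-c2nc3ccccn3c2Sc2ccccc2)cc1`: 50200 nM
Compound 2 `Clc1ccc(Sc2c(-c3cccs3)nc3ccccn23)cc1`: 59300 nM
Compound 3 `Cc1ccc2nc(-c3ccc(Cl)cc3)c(Sc3ccccc3)n2c1`: 63100 nM

The three compounds sit level on these numbers. Compound 1 (50200 nM) lies within the usual scatter of both compound 2 and compound 3, so this assay does not separate them.

The next compound to be tested is compound 4 `Clc1ccc(-c2nc3ccccn3c2Sc2ccccc2)cc1`, which keeps the core of compound 1 and changes one substituent, taking 4-ethylphenyl to 4-chlorophenyl. The change is chloro in place of ethyl on an aromatic carbon, para to a large group: chloro in place of ethyl on an aromatic carbon.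

Within the data shown here, no two measured compounds differ in only one place, so the data offer no direct precedent for the size of this step. The closest evidence is compound 3, which also carries a 4-chlorophenyl and has a further change in its core, and which gives a value (63100 nM) level with that of compound 1. On that basis, no shift beyond the scatter is expected in this assay. The estimated change is a 1.1-fold higher number from compound 1 to compound 4 (0.04 log units; within the scatter), and it has no firm direction. For compound 4 the estimate is 55000 nM, with an expected range of 27000 nM to 105000 nM in this measurement.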

Compound 4, half-maximal inhibitory concentration: 13900 nM
Compound 4: the middle estimate sits 4.0-fold (0.60 log units) above what was measured; measured number below the stated range.
By their numbers in this assay, from the lowest: compound 4; then compounds 1, 2 and 3 (each within the scatter of the next).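

In this assay, the place on the aromatic carbon para to a large group proves responsive: chloro in place of ethyl gives a 3.6-fold lower number from compound 1 to compound 4 (0.56 log units; beyond the scatter), a difference that the three level compounds could not reveal. Among these compounds, the chloro does not bring this by itself, since compound 3 carries the same 4-chlorophenyl and the single change of hydrogen in place of methyl on an aromatic carbon gives a 4.5-fold lower number from compound 3 to compound 4 (0.66 log units; beyond the scatter), so the lower number of compound 4 depends on the substituents at both places in this small set. No measured information here accounts for either step, and the data give no reason for the dependence between the two places.

Going by these compounds, what remains open is whether bromo, methoxy or an amine at the para place would follow chloro or stay level with ethyl, and whether ethyl would also respond to removing the methyl from the core. On these data alone, it is equally open whether the same chloro step would carry over to a series in which a thiophene, as in compound 2, replaces the substituted phenyl.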